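A Nitro Group Added to an Inactive Core

A few compounds are considered here, and "the series" means these few. Any claim that something is new, unique, unknown or untested is made for them only; others in the source may bear on it.

Measured compounds:
Compound 1, `COc1ccc(Oc2ccc([N+](=O)[O-])cc2-c2ccsc2S(=O)(=O)N2CCN(C(=O)Nc3ccc([N+](=O)[O-])cc3)CC2)cc1OC`, in a functional assay on HeLa cells (Homo sapiens) for inhibition, read by CCK-8 assay, with a stated time of 48 h; a higher number here means a weaker inhibitor, a lower number a stronger inhibitor: > 50000 nM, a limit of the assay.
Compound 2, `COc1ccc(Oc2ccccc2-c2ccsc2S(=O)(=O)N2CCN(C(=O)Nc3ccc([N+](=O)[O-])cc3)CC2)cc1OC`, in this assay: > 50000 nM, a limit of the assay.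
Compound 3, `O=S(=O)(c1sccc1-c1ccccc1Oc1ccc(O)c(O)c1)N1CCN(C(=S)Nc2cc(C(F)(F)F)cc(C(F)(F)F)c2)CC1`, in this assay: > 20000 nM, a limit of the assay.

None of the three measured compounds gives a number in this assay; all three sit at a limit, two of them at the limit of > 50000 nM in this assay, at which 2 of the 3 values shown sit, and one at the limit of > 20000 nM in this assay, at which 1 of the 3 values shown sits. The step from compound 2 to compound 1 is the change (nitro in place of hydrogen on an aromatic carbon), and its size is a step that the two limits leave unreadable from compound 2 to compound 1.

Compound 4, `O=[N+]([O-])c1ccc(Oc2ccc(O)c(O)c2)c(-c2ccsc2S(=O)(=O)N2CCN(C(=S)Nc3cc(C(F)(F)F)cc(C(F)(F)F)c3)CC2)c1`, has not yet been measured. It arises from compound 3 by the change (nitro in place of hydrogen on an aromatic carbon). Among the measured compounds shown here, this is the same kind of change as the one from compound 2 to compound 1, but the surroundings differ: in compound 4 the new group sits para to a 3,4-dihydroxyphenoxy group, whereas in compound 1 it sits para to a 3,4-dimethoxyphenoxy group. The difference between the core of compound 3 and the core of compound 2 is not broken down here.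

Compound 3 sits at a limit, and the earlier step of the same kind left both its compounds at a limit, so the step from compound 3 to compound 4 is expected to be a step that the limit leaves unreadable from compound 3 to compound 4. Compound 4 is expected to give about 30000 nM in this assay, between 8000 nM and 120000 nM, most likely again reported only as a limit.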

Compound 4, half-maximal inhibitory concentration: > 20000 nM
Compound 4: no number, only a limit; the forecaster's own chance of this, stated with the estimate: 75%; the middle value does not contradict the limit.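

In this assay compound 4 gives > 20000 nM, a limit of the assay. Compound 3 gives > 20000 nM, likewise a limit, and the size of the step between compound 3 and compound 4 cannot be read. The compounds shown leave open whether nitro in place of hydrogen changes the result in this assay at all, and none of the four gives a number there.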